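Trifluoromethyl in place of dimethylamino: notes on compound 4

The source may hold more compounds than are shown below. What is called first, only, known or untested is meant among the compounds shown, and "the series" means these compounds.

Measured so far in a functional assay on SiHa cells (Homo sapiens) for inhibition, read by sulforhodamine B assay; a higher number here means a weaker inhibitor of growth, a lower number a stronger inhibitor of growth
compound 1 `Cc1ccc2[nH]c(-c3ccc(-c4ccc(-c5ccc(N(C)C)cc5)cc4)cc3)nc2c1` gives 7110 nM
compound 2 `CN(C)c1ccc(-c2ccc(-c3ccc(-c4nc5ccccc5[nH]4)cc3)cc2)cc1` gives 100000 nM
compound 3 `CN(C)c1ccc(-c2ccc(-c3ccc(-c4nc5c(O)cccc5[nH]4)cc3)cc2)cc1` gives 6240 nM

Compound 1 stands level with compound 3 within the scatter (a 1.1-fold lower number from compound 1 to compound 3 (0.06 log units; within the scatter)) and well under compound 2, which has the highest number of the three. Compound 4 `Cc1ccc2[nH]c(-c3ccc(-c4ccc(-c5ccc(C(F)(F)F)cc5)cc4)cc3)nc2c1` is unmeasured and has trifluoromethyl in place of dimethylamino on an aromatic carbon, para to a large group (trifluoromethyl in place of dimethylamino on an aromatic carbon). Going by the values given here, no measured step replaces dimethylamino. The large steps (a 14-fold higher number from compound 1 to compound 2 (1.15 log units; beyond the scatter)) and (a 16-fold lower number from compound 2 to compound 3 (1.20 log units; beyond the scatter)) change a different group, so they show only that large steps occur among these compounds and give no direction here. No shift beyond the scatter is therefore expected. The expected step is a 1.0-fold lower number from compound 1 to compound 4 (0.01 log units; within the scatter), with wide uncertainty. For compound 4 the estimated value is 7000 nM (expected range 1500 nM to 35000 nM).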

Compound 4, concentration for 50% growth inhibition: 33200 nM
Estimate against measurement, compound 4: 4.7-fold (0.68 log units) below; measured number inside the range.
By their numbers in this assay, from the lowest: compounds 3 and 1 (each within the scatter of the next); then compound 4; then compound 2.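

In this assay trifluoromethyl in place of dimethylamino gives a 4.7-fold higher number from compound 1 to compound 4 (0.67 log units; beyond the scatter) on an aromatic carbon para to a large group. Going by these compounds alone, this is the first step at this position, and it shows that the position is not indifferent to the group it carries: 4-(dimethylamino)phenyl goes with the lower number and 4-(trifluoromethyl)phenyl with the higher. Nothing available bears on the cause of this step.

One step cannot separate a gain from dimethylamino from a loss from trifluoromethyl, and a methoxy group or a carboxylic acid here would help to do so. On these data alone, whether the step carries over to the cores of compound 2 and compound 3 stays open.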